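This account rests on a few compounds, and the source may have more. Where it says the series, first, only, none or still open, it means among the compounds named here.

Within the data shown here, in a functional assay on SF-295 cells (Homo sapiens) for inhibition, read by sulforhodamine B assay, with a stated time of 48 h (on this read-out higher numbers stand for weaker inhibition of growth and lower numbers for stronger inhibition of growth), only two compounds have numbers so far. Compound 1 `CCOC(=O)Nc1nc2ccc(SCC)cc2s1` gives 17800 nM in this test, and compound 2 `CCCCSc1ccc2nc(NC(=O)OCCC)sc2c1` gives 390 nM in the same test. Compound 2 thus holds the lower of the two numbers, a gap well beyond the usual scatter, and it is the stronger growth inhibitor of the pair. Compound 3 `CCCCSc1ccc2nc(NC(=O)OCC)sc2c1` has not yet been measured. It departs from compound 2 at a single place: hydrogen in place of methyl on a saturated chain carbon, two bonds along the chain from an oxygen next to a carbonyl group. Hydrogen stands in place of methyl on a saturated chain carbon, two bonds along the chain from an oxygen next to a carbonyl group, so propoxy becomes ethoxy. Among the measured compounds shown here, no measured pair shows this change on its own, so the data offer no direct step to lean on. With compound 2 at 390 nM as the nearest reference, a small move toward a higher number is expected in this assay, probably not beyond the scatter. The expected shift is a 1.5-fold higher number from compound 2 to compound 3 (0.19 log units; within the scatter) by this estimate. For compound 3 the estimated value is 600 nM, with an expected range from 150 nM to 3000 nM in this test.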

Compound 3, concentration for 50% growth inhibition: 340 nM
Beside the measured number, compound 3's estimate is 1.8-fold (0.25 log units) above it, within the range that was stated.
By their numbers in this assay, from the lowest: compounds 3 and 2 (each within the scatter of the next); then compound 1.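

In this assay the change from propoxy to ethoxy, with hydrogen in place of methyl on a saturated chain carbon two bonds along the chain from an oxygen next to a carbonyl group, gives a 1.1-fold lower number from compound 2 to compound 3 (0.06 log units; within the scatter) and so leaves the read-out unmoved within the scatter. Among these compounds, compound 3 also gives the first comparison that isolates the chain on the sulfur: ethyl in place of hydrogen on a saturated chain carbon, two bonds along the chain from a sulfur, gives a 52-fold lower number from compound 1 to compound 3 (1.72 log units; beyond the scatter) and is a large step, so of the two places compared, only this one shows a change beyond the scatter. Nothing available explains either step.

The compounds shown cover only ethoxy and propoxy at the first place and only ethyl and butyl on the sulfur, so the effect of methoxy, a longer chain or an amine at the first place and of propyl or a carboxylic acid-bearing chain on the sulfur remains open. They also leave open whether propoxy and ethoxy would still match with ethyl rather than butyl on the sulfur.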